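The source may hold more compounds than are shown below. What is called first, only, known or untested is meant among the compounds shown, and "the series" means these compounds.

Measured compounds:
- compound 1 `CN(Cc1ccccc1)CC1CCN(CCCc2c[nH]c3ccc(-n4cnnc4)cc23)CC1`: 0.9 nM
- compound 2 `CN(CC1CCN(CCCc2c[nH]c3ccc(-n4cnnc4)cc23)CC1)C(=O)Nc1ccccc1`: 5.9 nM
- compound 3 `C[C@@H](NCC1CCN(CCCc2c[nH]c3ccc(-n4cnnc4)cc23)CC1)c1ccccc1`: 1.4 nM

In an assay on CHO cells for displacement of a labelled ligand from 5-hydroxytryptamine receptor 1D (Homo sapiens) (on this read-out higher numbers stand for weaker inhibition and lower numbers for stronger inhibition), compound 1 gives the lowest of the three numbers; compound 3 sits within the scatter of it, while compound 2 lies further off, a 6.6-fold higher number from compound 1 to compound 2 (0.82 log units; beyond the scatter). Compound 4 `O[C@@H]1Cc2ccccc2[C@H]1NC1CCN(CCCc2c[nH]c3ccc(-n4cnnc4)cc23)CC1` is not yet measured. Relative to compound 1 the change is (2-hydroxy-2,3-dihydro-1H-inden-1-yl)amino in place of (benzyl(methyl)amino)methyl on a saturated ring carbon. Among the measured compounds shown here, two measured steps bear on it. The step of a 1.6-fold higher number from compound 1 to compound 3 (0.19 log units; within the scatter) shows that a secondary amine carrying a phenyl-bearing group keeps the number close to that of compound 1. The step of a 6.6-fold higher number from compound 1 to compound 2 (0.82 log units; beyond the scatter) shows that replacing benzyl with phenylcarbamoyl weakens modestly. The change to compound 4 is larger than either, removing the methylene linker and adding a hydroxyl, so a modest rise is expected, a 3.3-fold higher number from compound 1 to compound 4 (0.52 log units; beyond the scatter). Compound 4 is estimated at 3 nM (range 0.8 nM to 12 nM).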

Compound 4, half-maximal inhibitory concentration: 6.6 nM
Beside the measured number, compound 4's estimate is 2.2-fold (0.34 log units) below it; low and high end bracket the measured number.
By their numbers in this assay, from the lowest: compounds 1 and 3 (each within the scatter of the next); then compounds 2 and 4 (each within the scatter of the next).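

With a 7.3-fold higher number from compound 1 to compound 4 (0.87 log units; beyond the scatter) and a 4.7-fold higher number from compound 3 to compound 4 (0.67 log units; beyond the scatter) in this assay the (2-hydroxy-2,3-dihydro-1H-inden-1-yl)amino group on this saturated ring carbon lies beyond the scatter of both comparators. A secondary amine carrying a phenyl-bearing group therefore does not by itself keep the number near those of compound 1 and compound 3. No measurement on hand accounts for the rise.

The change alters the linker, ring and hydroxyl at once, so their contributions remain unseparated. The plain (2,3-dihydro-1H-inden-1-yl)amino group and a benzylamino group on the same ring carbon would begin to divide them.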